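Moving a chlorine on the amide-side phenyl ring

This account rests on a few compounds, and the source may have more. Where it says the series, first, only, none or still open, it means among the compounds named here.

Compound 1, `O=C(CSc1nc(Nc2ccccc2)c2ccccc2n1)Nc1ccccc1F`, in a functional assay on PC-3 cells (Homo sapiens) for inhibition, read by MTT assay, with a stated time of 72 h; a lower number here means a stronger inhibitor, a higher number a weaker inhibitor: 12400 nM
Compound 2, `O=C(CSc1nc(Nc2ccccc2)c2ccccc2n1)Nc1ccc(C(F)(F)F)cc1`: 10400 nM
Compound 3, `O=C(CSc1nc(Nc2ccccc2)c2ccccc2n1)Nc1ccc(Cl)cc1Cl`: 9110 nM

All three compounds share one core and differ only in the ring carried on the amide-type nitrogen. Compound 3 gives the lowest of the three numbers, yet the step of a 1.1-fold lower number from compound 2 to compound 3 (0.06 log units; within the scatter) and the step of a 1.4-fold lower number from compound 1 to compound 3 (0.13 log units; within the scatter) both lie within the scatter, so no ranking can be read from them; the same holds for a 1.2-fold lower number from compound 1 to compound 2 (0.08 log units; within the scatter). Compound 4, `O=C(CSc1nc(Nc2ccccc2)c2ccccc2n1)Nc1ccc(Cl)c(Cl)c1`, has not yet been measured. It differs from compound 3 by 3,4-dichlorophenyl in place of 2,4-dichlorophenyl on an amide-type nitrogen. Within the data shown here, no measured step compares two dichlorophenyl groups with each other; the three steps at hand only show that exchanging fluorine, trifluoromethyl and two chlorines on this ring leaves the number essentially where it was. On that basis the estimated step of a 1.0-fold higher number from compound 3 to compound 4 (0.02 log units; within the scatter) is expected to stay within the scatter, in no particular direction. Compound 4 is therefore estimated at 9500 nM, with a range from 4500 nM to 20000 nM.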

Compound 4, half-maximal inhibitory concentration: 12100 nM
Compound 4: middle estimate off by 1.3-fold (0.11 log units), on the low side, within the range that was stated.
By their numbers in this assay, from the lowest: compounds 3, 2, 4 and 1 (each within the scatter of the next).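

Among these compounds, compound 4 gives the first comparison of two dichlorophenyl groups on this amide-type nitrogen. In this assay, putting 3,4-dichlorophenyl in place of 2,4-dichlorophenyl, with the same atoms joined differently, gives a 1.3-fold higher number from compound 3 to compound 4 (0.12 log units; within the scatter), so this rearrangement produces no readable difference. The steps of a 1.2-fold higher number from compound 2 to compound 4 (0.07 log units; within the scatter) and a 1.0-fold lower number from compound 1 to compound 4 (0.01 log units; within the scatter) also stay inside the scatter, so the four rings shown at this position cannot be told apart in this assay, and no available measurement helps to interpret this result.

From the compounds shown here alone, all four rings carry only fluorine, chlorine or trifluoromethyl, so it remains open whether a ring bearing a carboxylic acid or an amine, or a longer chain at this nitrogen, would give a different number. The rest of the shared core is identical throughout, which leaves the effect of changes there open as well.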